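A methyl on the hydroxy-lactone oxygen: a small step

The compounds below may be only part of what the source reports. "The series", "measured", "known", "first", "only" and "open" are said of these compounds alone.

Of the compounds shown here, two built on the same core have so far been tested in a functional assay on A549 cells (Homo sapiens) for inhibition, read by sulforhodamine B assay; a higher number here means a weaker inhibitor of growth, a lower number a stronger inhibitor of growth. Compound 1, `C=C1CC[C@H]2C(C)(C)CCC[C@]2(C)[C@H]1C/C=C1/CC(O)OC1=O`, gives 8000 nM in this assay, the higher of the two numbers measured. Compound 2, `C=C1CC[C@H]2C(C)(C)CCC[C@]2(C)[C@H]1CCC1=CC(O)OC1=O`, gives 4800 nM in this assay, and its gap to compound 1 is within the usual scatter, so the two cannot be told apart on these data.

The next compound, compound 3, `C=C1CC[C@H]2C(C)(C)CCC[C@]2(C)[C@H]1C/C=C1/CC(OC)OC1=O`, keeps the core and the unsaturated side chain of compound 1 and changes only one place: methyl in place of hydrogen on an oxygen on a saturated carbon. Seen one bond further out, this is hydroxy to methoxy. Going by the values given here, no measured pair in this set shows what such a change does, so there is no step to lean on. A single methyl added at an oxygen is a small change, and the expected step in this assay a 1.1-fold lower number from compound 1 to compound 3 (0.06 log units; within the scatter) is therefore small, with no clear direction beyond the scatter. Compound 3 is estimated at 7000 nM in this assay, with a likely range from 2500 nM to 20000 nM.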

Compound 3, concentration for 50% growth inhibition: 30000 nM
For compound 3 the middle estimate is 4.3-fold (0.63 log units) below the measured one; the measured number lies above the stated range.
By their numbers in this assay, from the lowest: compounds 2 and 1 (each within the scatter of the next); then compound 3.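

This position is not indifferent to change. In this assay, methyl in place of hydrogen on an oxygen on a saturated carbon, which is hydroxy to methoxy, gives a 3.8-fold higher number from compound 1 to compound 3 (0.57 log units; beyond the scatter), so this small edit makes compound 3 a weaker inhibitor of growth than compound 1, by a margin the usual scatter does not cover. Going by these compounds alone, the earlier compounds could not show this, as compounds 1 and 2 offered no step of their own and their numbers could not be told apart, whereas this pair differs in one place only and gives the first readable step in the set. Nothing measured here bears on what lies behind the step.

On these data alone, it remains open whether the free hydroxy itself matters or whether only the added methyl counts, and an ethyl ether, an acetate ester or an amine at the same carbon would help to separate those two readings. As far as these compounds go, it is also open whether the same hydroxy to methoxy change would give a step of similar size on compound 2, whose side chain differs from that of compound 1.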